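A few compounds are considered here, and "the series" means these few. Any claim that something is new, unique, unknown or untested is made for them only; others in the source may bear on it.

Of the compounds shown here, two of one family have been measured in a functional assay on A549 cells (Homo sapiens) for cytotoxicity, read by sulforhodamine B assay, with a stated time of 48 h, tested at 100 uM; a lower number here means a stronger effect, a higher number a weaker effect of the compound at the concentration tested. Compound 1 `COc1ccc(-c2cc(/C=C/C(=O)c3ccc(N)cc3)[nH]n2)cc1` gives -75%. Compound 2 `COc1cc(-c2cc(/C=C/C(=O)c3ccc(Cl)c(Cl)c3)[nH]n2)cc(OC)c1OC` gives 2%, the higher of the two numbers; its nearest neighbour, compound 1, lies far enough below it that the gap is beyond the usual scatter of this kind of measurement. Compound 3 `COc1cc(-c2cc(/C=C/C(=O)c3ccc(F)c(F)c3)[nH]n2)cc(OC)c1OC` has not yet been measured. It differs from compound 2 in one place: 3,4-difluorophenyl in place of 3,4-dichlorophenyl on a carbonyl carbon. Among the measured compounds shown here, no measured pair shows what such a swap does, so the expected step is a number 3 percentage points higher from compound 2 to compound 3 (within the scatter), small and in no certain direction. Compound 3 is therefore estimated to give about 5%, with a range from -20% to 30%.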

Compound 3, a percentage reported as activity, at one concentration (the size of the read-out at that concentration, not a potency): -15%
For compound 3 the middle estimate is 20 percentage points above the measured one; the range from low to high includes it.
By their numbers in this assay, from the lowest: compound 1; then compound 3; then compound 2.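

Among the compounds shown here, this is the first measured step at the group on the carbonyl carbon. In this assay, 3,4-difluorophenyl in place of 3,4-dichlorophenyl gives a number 17 percentage points lower from compound 2 to compound 3 (beyond the scatter) and so shifts the read-out, although the two groups match in heavy-atom count and ring. No measurement here gives a reason for this step.

A plain phenyl or a methoxyphenyl on the same carbonyl carbon would show whether the read-out depends on halogens at all. Going by these compounds, whether this swap acts the same way on the core of compound 1 also remains open.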